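A larger group on the amine nitrogen of compound 2

The source may hold more compounds than are shown below. What is called first, only, known or untested is meant among the compounds shown, and "the series" means these compounds.

In a functional assay on HeLa cells (Homo sapiens) for inhibition, read by MTT assay, with a stated time of 48 h (a lower number here means a stronger inhibitor, a higher number a weaker inhibitor), compound 1 (`CCOC(=O)C1=C(N/N=C(\c2ccc([N+](=O)[O-])cc2)N2CCN(c3ccc(F)cc3)CC2)Nc2[nH]nc(C)c2C1c1ccc(N(C)C)cc1`) gives 87000 nM and compound 2 (`CCOC(=O)C1=C(NN=C(C#N)C#N)Nc2[nH]nc(C)c2C1c1ccc(N(C)C)cc1`) gives 15200 nM as the lower of the two numbers. Compound 2 is therefore the stronger inhibitor of this pair, by more than the usual scatter of repeated measurements.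

Compound 3 (`CCOC(=O)C1=C(N/N=C(/C(=O)Br)c2ccc(Cl)cc2)Nc2[nH]nc(C)c2C1c1ccc(N(C)C)cc1`) keeps the shared core but carries a different group on the amine nitrogen whose other neighbour is the double-bonded ring carbon: a group of 12 heavy atoms (8 carbon, 1 nitrogen, 1 oxygen, 1 chlorine, 1 bromine; one six-membered aromatic ring of carbon only) in place of a group of 6 heavy atoms (3 carbon, 3 nitrogen; no ring), on an amine nitrogen. The group that enters holds one six-membered aromatic ring of carbon only.

Going by the values given here, no measured pair isolates this change, so the data give no direct size for the step. Among the compounds with values here, the only guide is compound 1, which also bears a larger group at that nitrogen and reads 87000 nM in this assay. On that single comparison, a moderate rise in the number is expected, a little beyond the scatter, with the estimated change being a 2.3-fold higher number from compound 2 to compound 3 (0.36 log units; beyond the scatter) overall. For compound 3 the expected value is 35000 nM, with an estimated range from 12000 nM to 100000 nM.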

Compound 3, half-maximal inhibitory concentration: 49300 nM
Compound 3: the middle estimate sits 1.4-fold (0.15 log units) below what was measured; the range from low to high includes it.
By their numbers in this assay, from the lowest: compound 2; then compounds 3 and 1 (each within the scatter of the next).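

In this assay the exchange on the amine nitrogen whose other neighbour is the double-bonded ring carbon gives a 3.2-fold higher number from compound 2 to compound 3 (0.51 log units; beyond the scatter) as its first directly read step at this place, so the higher number seen with a larger group is no longer tied to compound 1 alone. The two larger groups differ from each other, yet compound 3 at 49300 nM and compound 1 at 87000 nM lie within the scatter of each other, and among these three compounds the group of 6 heavy atoms with no ring, in compound 2, remains the one with the lowest number. No measured evidence here accounts for this step.

The step cannot be assigned to any single feature, since the chlorine, the bromine, the carbonyl and the six-membered aromatic ring enter together while both nitrile groups leave. A plain phenyl group, a short alkyl chain, an amine or a carboxylic acid on this amine nitrogen would help separate these contributions, and the three compounds shown do not tell whether group size or another feature goes with the number.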